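The source may report more compounds than this note shows. Statements on the series, on what has been measured and on what is new or still open speak of the compounds shown alone.

Series notes. Compound 1 `COc1ccc(CN(C(=O)CCl)c2cc(OC)c(OC)c(OC)c2)cc1O` is measured in a functional assay on KYSE-450 cells (Homo sapiens) for inhibition, read by MTT assay, with a stated time of 48 h (a higher number here means a weaker inhibitor, a lower number a stronger inhibitor), at 210 nM, the lowest of the three numbers in hand. Compound 2 `COc1ccc(CNc2cc(OC)c(OC)c(OC)c2)cc1` gives 4890 nM in this assay, and compound 3 `COc1ccc(CNc2cc(OC)c(OC)c(OC)c2)cc1F` gives 46200 nM. Compound 1 differs from compound 2 in more than one place, so their two values only show that compound 1 sits well below compound 2. Within the data shown here, the one single-point step available is a 9.4-fold higher number from compound 2 to compound 3 (0.98 log units; beyond the scatter), which concerns a fluoro on an aromatic ring and says nothing directly about the acyl group.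

Compound 4 `COc1ccc(CN(C(=O)C=C(C)C)c2cc(OC)c(OC)c(OC)c2)cc1O` is not yet measured. It differs from compound 1 as follows: 2-methylprop-1-en-1-yl in place of chloromethyl on a carbonyl carbon. Among the measured compounds shown here, no measured pair varies the group on the carbonyl carbon, so there is no step to lean on for this change. The expectation is that compound 4 gives a higher number than compound 1 in this assay, with a step of a 4.8-fold higher number from compound 1 to compound 4 (0.68 log units; beyond the scatter), though the width of that guess is considerable. Compound 4 is therefore estimated at 1000 nM, within a range from 300 nM to 5000 nM.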

Compound 4, half-maximal inhibitory concentration: 280 nM
Estimate against measurement, compound 4: 3.6-fold (0.55 log units) above; measured number below the stated range.
By their numbers in this assay, from the lowest: compounds 1 and 4 (each within the scatter of the next); then compound 2; then compound 3.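

In this assay, the first change measured on a carbonyl carbon whose other neighbour is the amide-type nitrogen gives a 1.3-fold higher number from compound 1 to compound 4 (0.12 log units; within the scatter), so chloromethyl and 2-methylprop-1-en-1-yl cannot be told apart here. This position therefore holds both a group of 2 heavy atoms with a chlorine and a group of 4 carbons with a double bond, and the chlorine is not required for a value in this range, as compound 4 at 280 nM shows. Nothing at hand explains why the two groups read alike.

Going by these compounds, whether a saturated 2-methylpropyl chain or an aminomethyl group on the same carbonyl carbon would read alike remains open. Among the compounds shown, neither compound 1 nor compound 4 has a partner differing only by the loss of the acyl group, so its contribution stays unread.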